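Pyridin-4-yl replaces fluoropyridinyl in an HT-29 series

The compounds below may be only part of what the source reports. "The series", "measured", "known", "first", "only" and "open" are said of these compounds alone.

Measured compounds:
compound 1 `COc1ccc(S(=O)(=O)N2CCc3cccc(-c4ccc(F)nc4)c32)cc1`, 109 nM
compound 2 `COc1ccc(S(=O)(=O)N2CCc3cccc(-c4ccco4)c32)cc1`, 62.5 nM

In a functional assay on HT-29 cells (Homo sapiens) for inhibition, with a stated time of 72 h (on this read-out lower numbers stand for stronger inhibition and higher numbers for weaker inhibition), compound 1 gives the higher of the two numbers; its nearest neighbour, compound 2, gives 62.5 nM, and the step of a 1.7-fold lower number from compound 1 to compound 2 (0.24 log units; within the scatter). Compound 3 `COc1ccc(S(=O)(=O)N2CCc3cccc(-c4ccncc4)c32)cc1` differs from compound 1 by pyridin-4-yl in place of 6-fluoropyridin-3-yl on an aromatic carbon. Going by the values given here, the only measured step, from compound 1 to compound 2, swaps the same group for another and stays within the scatter, so compound 3 is expected to show no step beyond the scatter: a 1.1-fold lower number from compound 1 to compound 3 (0.04 log units; within the scatter). For compound 3 the estimate is 100 nM, expected to lie between 40 nM and 250 nM.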

Compound 3, half-maximal inhibitory concentration: 87.5 nM
Beside the measured number, compound 3's estimate is 1.1-fold (0.06 log units) above it; the range from low to high includes it.
By their numbers in this assay, from the lowest: compounds 2, 3 and 1 (each within the scatter of the next).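

In this assay, pyridin-4-yl at this aromatic carbon gives a 1.2-fold lower number from compound 1 to compound 3 (0.10 log units; within the scatter), and set against furan-2-yl it gives a 1.4-fold higher number from compound 2 to compound 3 (0.15 log units; within the scatter). This position therefore carries three different aromatic rings with all steps within the scatter, and the fluorine of 6-fluoropyridin-3-yl is not required to stay in this range. Nothing available explains why these numbers stay so close. On these data alone, whether an amine or a carboxylic acid on this ring would give a step beyond the scatter remains open. The loss of fluorine also cannot be told apart from the move from a pyridin-3-yl to a pyridin-4-yl attachment.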